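Extending the benzylamine chain on a triazine core

This account rests on a few compounds, and the source may have more. Where it says the series, first, only, none or still open, it means among the compounds named here.

Compound 1 `Nc1nc(NCc2ccccc2)nc(-c2ccccc2CO)n1`: 4.35
Compound 2 `COc1ccccc1CNc1nc(N)nc(-c2ccccc2CO)n1`: 3.99

In a functional assay on cells for positive allosteric modulation of G-protein coupled receptor 68 (Homo sapiens), read by a luciferase reporter and cAMP accumulation, with a stated time of 30 min, at pH 6.8 and pH 8.3, in the presence of a further agent that is not named here (a lower number here means a less potent compound, a higher number a more potent compound, by a factor of ten per unit of this negative logarithm), compound 2 gives 3.99, the lower of the two numbers, while compound 1 gives 4.35. Going by the values given here, the one measured step, a number 0.36 log units lower from compound 1 to compound 2 (beyond the scatter), came from the methoxy substituent alone. Compound 3 `Nc1nc(NCCCc2ccccc2)nc(-c2ccccc2CO)n1` differs from compound 2 by phenethyl in place of 2-methoxyphenyl on a saturated chain carbon bound to a nitrogen on an aromatic ring. Among the compounds with values here, that removes the methoxy that cost potency in a number 0.36 log units lower from compound 1 to compound 2 (beyond the scatter), but no measured pair shows the effect of a longer chain. Compound 3 is therefore expected near compound 1, with a number 0.31 log units higher from compound 2 to compound 3 (beyond the scatter) as the estimated step, giving 4.3 within 3.7 to 4.8.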

Compound 3, negative logarithm of the antagonist equilibrium constant: 5.22
The estimate for compound 3 lay 0.92 log units below the measured number; measured number outside the range, above it.
By their numbers in this assay, from the lowest: compound 2; then compound 1; then compound 3.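

Phenethyl on a saturated chain carbon bound to a nitrogen on an aromatic ring does more than undo the loss seen with the methoxy: the change gives a number 1.23 log units higher from compound 2 to compound 3 (beyond the scatter). Compared with phenyl at the same place, which carries no methoxy, it still gives a number 0.87 log units higher from compound 1 to compound 3 (beyond the scatter), so this position tolerates phenethyl and gains from it. Nothing available explains this gain.

Going by these compounds, a longer chain, or an amine within the chain, remains open. So does whether a methoxy on the phenethyl would cost potency as it did in compound 2.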